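Cytotoxicity notes: the step from compound 3 to compound 4

The source may report more compounds than this note shows. Statements on the series, on what has been measured and on what is new or still open speak of the compounds shown alone.

Measured in an ADME assay on P3HR-1 cells (Homo sapiens) for cytotoxicity, read by microscopy and trypan blue exclusion, with a stated time of 2 days; on this read-out higher numbers stand for lower toxicity in this test and lower numbers for higher toxicity in this test:
compound 1, `COc1cc([C@@H](O)[C@@H](C)Oc2ccc([C@@H]3O[C@H](c4ccc(O)c(OC)c4)[C@H](C)[C@H]3C)cc2OC)ccc1O`, gives 23200 nM.
compound 2, `C=CCc1cc(OC)c(O[C@H](C)[C@H](OC(C)=O)c2cc(OC)c(OC)c(OC)c2)c(OC)c1`, gives 85000 nM.
compound 3, `COc1cc(C(=O)[C@@H](C)Oc2c(OC)cc(/C=C/CO)cc2OC)cc(OC)c1OC`, gives > 200000 nM, which is a limit of the test and not a number.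

Of the three values, compound 1 and compound 2 are numbers, while compound 3 sits at the limit of > 200000 nM in this assay, at which 1 of the 3 values shown sits. Among the measured compounds shown here, compound 3 therefore stands at the least toxic end of what has been measured, with no exact value known for it, and no step between measured compounds that differ in one place has been recorded.

The unmeasured compound 4, `C=CCc1cc(OC)c(O[C@H](C)C(=O)c2cc(OC)c(OC)c(OC)c2)c(OC)c1`, differs from compound 3 in one place: allyl in place of 3-hydroxyprop-1-en-1-yl on an aromatic carbon. Compound 2 also carries an allyl group on its aromatic ring and gives a number rather than a limit, but compound 2 and compound 4 differ in more than one place, so only their two values can be set side by side.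

On this basis the change is expected to make little difference beyond the scatter of this assay, with compound 4 likely remaining weakly cytotoxic. Compound 4 is therefore expected to give about 150000 nM, in a range from 60000 nM to 300000 nM. That estimate corresponds to an expected at least 1.3-fold lower number from compound 3 to compound 4 (0.12 log units; that floor lies within the scatter), within the scatter.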

Compound 4, half-maximal cytotoxic concentration: > 200000 nM
Compound 4: no number, only a limit; the forecaster's own chance of this, stated with the estimate: 45%; middle value at least 1.3-fold (0.12 log units) from the limit.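

Compound 3 and compound 4 both stand at a limit of the test and not at a number, so no step between them can be read: the limit of > 200000 nM in this assay, at which 2 of the 4 values shown sit.

The compounds shown leave open how far, and in which direction, allyl in place of 3-hydroxyprop-1-en-1-yl on the aromatic carbon moves the half-maximal cytotoxic concentration.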